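Fluoro in Place of Hydrogen: Outlook for Compound 4

This account rests on a few compounds, and the source may have more. Where it says the series, first, only, none or still open, it means among the compounds named here.

Three compounds of the series have been run in an assay on mitochondria from L6 cells (Rattus norvegicus) for activation, with a stated time of 90 min; on this read-out lower numbers stand for an effect already at smaller amounts and higher numbers for an effect only at larger amounts of compound. Compound 1 `CCCCCCc1ccc(Nc2nc3nonc3nc2O)cc1` gives 4700 nM in this assay. Compound 2 `CCCCCCc1ccc(Nc2nc3nonc3nc2O)c(F)c1` differs from compound 1 by fluoro in place of hydrogen on an aromatic carbon; in this assay compound 2 gives 3300 nM, the step being a 1.4-fold lower number from compound 1 to compound 2 (0.15 log units; within the scatter). Compound 3 `Oc1nc2nonc2nc1Nc1ccc(C(F)(F)F)cc1` carries the change trifluoromethyl in place of hexyl on an aromatic carbon relative to compound 1; in this assay compound 3 gives 10400 nM, the step being a 2.2-fold higher number from compound 1 to compound 3 (0.34 log units; beyond the scatter); compound 3 thus has the highest number of the three measured.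

Compound 4 `Oc1nc2nonc2nc1Nc1ccc(C(F)(F)F)cc1F` has not yet been measured. It differs from compound 3 by fluoro in place of hydrogen on an aromatic carbon, the same kind of change as that between compound 1 and compound 2, with the difference that the entering fluoro here stands meta to a trifluoromethyl group rather than meta to a hexyl group. Going by the values given here, the one earlier instance, a 1.4-fold lower number from compound 1 to compound 2 (0.15 log units; within the scatter), stayed within the scatter, and a similarly small movement is expected here. For compound 4 the estimated step is a 1.3-fold lower number from compound 3 to compound 4 (0.11 log units; within the scatter). Compound 4 is therefore expected to give about 8000 nM in this assay, with a range from 4500 nM to 14000 nM.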

Compound 4, half-maximal effective concentration: 2600 nM
For compound 4 the middle estimate is 3.1-fold (0.49 log units) above the measured one; the measured number lies below the stated range.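

In this assay the new step is a 4.0-fold lower number from compound 3 to compound 4 (0.60 log units; beyond the scatter), and set beside the earlier one, the fluoro change does not carry over from the hexyl compounds to the trifluoromethyl compounds at the same size: the same change on two cores in this assay, a 1.4-fold lower number (0.15 log units; within the scatter) from compound 1 to compound 2 and a 4.0-fold lower number (0.60 log units; beyond the scatter) from compound 3 to compound 4, 2.8-fold (0.45 log units) apart, beyond the scatter of two such steps. Read the other way, trifluoromethyl in place of hexyl comes to a 1.3-fold lower number from compound 2 to compound 4 (0.10 log units; within the scatter) once the fluoro is present, which also differs from the step without it: the same change on two cores in this assay, a 2.2-fold higher number (0.34 log units; beyond the scatter) from compound 1 to compound 3 and a 1.3-fold lower number (0.10 log units; within the scatter) from compound 2 to compound 4, 2.8-fold (0.45 log units) apart, beyond the scatter of two such steps. The two changes are therefore not additive across these compounds, so a step read on one core is a poor guide to the next, but a single set of four compounds gives no reason for the gap and no general rule for the series.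

Still open, going by these compounds, is whether the larger fluoro step belongs to trifluoromethyl alone or would also appear with a nitrile, a methoxy group or a shorter alkyl chain in its place. Also open, on these data alone, is whether a chlorine in place of the fluoro would behave in the same way.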